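From trifluoromethoxy to trifluoromethyl in compound 4

The source may report more compounds than this note shows. Statements on the series, on what has been measured and on what is new or still open speak of the compounds shown alone.

Compound 1 `Cc1cc(Nc2ccc(C(=O)/C=C/c3ccc(F)cc3)cc2)n2nc(SCc3nc4ccccc4[nH]3)nc2n1`: 85 nM
Compound 2 `COc1ccc(/C=C/C(=O)c2ccc(Nc3cc(C)nc4nc(SCc5nc6ccccc6[nH]5)nn34)cc2)cc1`: 170 nM
Compound 3 `Cc1cc(Nc2ccc(C(=O)/C=C/c3ccc(OC(F)(F)F)cc3)cc2)n2nc(SCc3nc4ccccc4[nH]3)nc2n1`: 220 nM

In a functional assay on SW-620 cells (Homo sapiens) for cytotoxicity, read by MTT assay, with stated times of 4 h and 72 h, tested at 2 uM (on this read-out lower numbers stand for stronger inhibition and higher numbers for weaker inhibition), compound 3 gives 220 nM as its reading. The data show a 1.3-fold higher number from compound 2 to compound 3 (0.11 log units; within the scatter) and so no real separation there, but also a 2.6-fold higher number from compound 1 to compound 3 (0.41 log units; beyond the scatter) as a modest weakening.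

Compound 4 `Cc1cc(Nc2ccc(C(=O)/C=C/c3ccc(C(F)(F)F)cc3)cc2)n2nc(SCc3nc4ccccc4[nH]3)nc2n1` keeps the rest of the structure and changes one group: trifluoromethyl in place of trifluoromethoxy on an aromatic carbon, para to a large group (trifluoromethyl in place of trifluoromethoxy on an aromatic carbon). For the measured compounds named here, no measured step makes this exact swap. Other swaps at this place have moved the number little: a 2.0-fold higher number from compound 1 to compound 2 (0.30 log units; within the scatter) for one and, largest of the three, a 2.6-fold higher number from compound 1 to compound 3 (0.41 log units; beyond the scatter) in this small set. A change beyond the scatter is therefore not expected, and the direction is uncertain. The expected step is a 1.2-fold lower number from compound 3 to compound 4 (0.09 log units; within the scatter) by this estimate. In this assay the estimate for compound 4 is 180 nM as the middle, with 75 nM to 430 nM as the expected range.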

Compound 4, half-maximal inhibitory concentration: 1850 nM
The estimate for compound 4 lay 10-fold (1.01 log units) below the measured number; the measured number lies above the stated range.
By their numbers in this assay, from the lowest: compounds 1, 2 and 3 (each within the scatter of the next, the first and the last beyond it); then compound 4.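

In this assay, for the compounds shown here, this position on the aromatic ring proves far more sensitive than the earlier compounds suggested: trifluoromethyl brings an 8.4-fold higher number from compound 3 to compound 4 (0.92 log units; beyond the scatter), as well as an 11-fold higher number from compound 2 to compound 4 (1.04 log units; beyond the scatter) and a 22-fold higher number from compound 1 to compound 4 (1.34 log units; beyond the scatter). Among fluoro, methoxy and trifluoromethoxy, the largest step was only a 2.6-fold higher number from compound 1 to compound 3 (0.41 log units; beyond the scatter), whereas here taking away just the oxygen of trifluoromethoxy separates compound 4 clearly from the other three. The data shown offer no explanation for this jump.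

The compounds shown leave open whether the sharp loss belongs to trifluoromethyl alone or extends to other groups at this position, such as a methyl, a nitrile or a carboxylic acid. They also leave open whether the same swap would have so large an effect on a different core.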